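A few compounds are considered here, and "the series" means these few. Any claim that something is new, unique, unknown or untested is made for them only; others in the source may bear on it.

In an in vitro assay on BHK cells for inhibition of Glucagon receptor (Homo sapiens) (on this read-out higher numbers stand for weaker inhibition and lower numbers for stronger inhibition), the measured compounds are:
compound 1 `CCCCC(CC)N(Cc1ccc(C(=O)NCCC(=O)O)cc1)C(=O)Nc1ccc(OC(F)(F)F)cc1`: 141 nM
compound 2 `O=C(O)CCNC(=O)c1ccc(CN(C(=O)Nc2ccc(OC(F)(F)F)cc2)C2CCC(C(=O)O)CC2)cc1`: > 10000 nM, a limit of the assay the limit of > 10000 nM in this assay, at which 1 of the 3 values shown sits.
compound 3 `CCN(CC)C(=O)C1CCC(N(Cc2ccc(C(=O)NCCC(=O)O)cc2)C(=O)Nc2ccc(OC(F)(F)F)cc2)CC1`: 782 nM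

Compound 3 has the highest of the two numbers given; the nearest is compound 1, with a clearly lower number. Compound 4 `CCCC1CCC(N(Cc2ccc(C(=O)NCCC(=O)O)cc2)C(=O)Nc2ccc(OC(F)(F)F)cc2)CC1` has not been measured. It differs from compound 3 in one place: propyl in place of diethylcarbamoyl on a saturated ring carbon. For the measured compounds named here, two measured steps bear on this. an at least 70-fold higher number from compound 1 to compound 2 (1.85 log units; beyond the scatter), and an at least 12-fold lower number from compound 2 to compound 3 (1.10 log units; beyond the scatter), so changes at this ring carbon have moved the number strongly in both directions. Compound 1, which carries 1-ethylpentyl here, has the lowest number. The step to compound 4 is therefore expected to lower the number, a 3.1-fold lower number from compound 3 to compound 4 (0.50 log units; beyond the scatter). For compound 4 the estimate in this assay is 250 nM, between 80 nM and 800 nM.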

Compound 4, half-maximal inhibitory concentration: 122 nM
For compound 4 the middle estimate is 2.0-fold (0.31 log units) above the measured one, within the range that was stated.
By their numbers in this assay, from the lowest: compounds 4 and 1 (each within the scatter of the next); then compound 3. At a limit, above all of these: compound 2.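

Replacing diethylcarbamoyl with propyl on this saturated ring carbon gives a 6.4-fold lower number from compound 3 to compound 4 (0.81 log units; beyond the scatter) and so shows that a plain carbon chain works better here than this amide. Replacing carboxy with propyl gives an at least 81-fold lower number from compound 2 to compound 4 (1.91 log units; beyond the scatter) as a bound only, since the value of compound 2 is a limit: the limit of > 10000 nM in this assay, at which 1 of the 4 values shown sits.
The 4-propylcyclohexyl and 1-ethylpentyl groups on the amide-type nitrogen match closely, with a 1.2-fold lower number from compound 1 to compound 4 (0.06 log units; within the scatter) as the step between them.

On these data alone, whether a butyl chain, an amine or an alcohol on this ring carbon would match propyl stays open.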